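Removing the Nitro Group from Compound 1

This account rests on a few compounds, and the source may have more. Where it says the series, first, only, none or still open, it means among the compounds named here.

compound 1: `COc1cc(OC)c2c(=O)cc(/C=C/c3ccc([N+](=O)[O-])cc3)oc2c1` — > 40000 nM
compound 2: `COc1ccc2oc(/C=C/c3ccc(OC(F)(F)F)cc3)cc(=O)c2c1` — > 40000 nM

Two compounds were examined in a functional assay on PC-3 cells (Homo sapiens) for antiproliferative activity, read by MTT assay, with a stated time of 12 h; a lower number here means a stronger inhibitor, a higher number a weaker inhibitor. In this assay compound 1 `COc1cc(OC)c2c(=O)cc(/C=C/c3ccc([N+](=O)[O-])cc3)oc2c1` gives > 40000 nM, which is a limit of the assay and not a number. Compound 2 `COc1ccc2oc(/C=C/c3ccc(OC(F)(F)F)cc3)cc(=O)c2c1` was tested in the same assay, and there compound 2 gives > 40000 nM, again a limit rather than a number. Within the data shown here, compound 1 therefore stands only at the limit of > 40000 nM in this assay, at which 2 of the 2 values shown sit, so no measured number places it above or below anything else, and no step between measured compounds can be sized.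

Compound 3 `COc1cc(OC)c2c(=O)cc(/C=C/c3ccccc3)oc2c1` differs from compound 1 in one place: hydrogen in place of nitro on an aromatic carbon. Since compound 1 sits at a limit, no step size can be read from it, and the expectation for compound 3 is of no step beyond the scatter and a result most likely still at the limit. Compound 3 is expected at 50000 nM, with a range from 20000 nM to 200000 nM. The expected step is a step that the limit leaves unreadable from compound 1 to compound 3.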

Compound 3, half-maximal inhibitory concentration: > 40000 nM
Compound 3: only a limit was reported; the forecaster's own chance of this, stated with the estimate: 75%; the middle value is on the limit's open side.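

In this assay compound 3 gives > 40000 nM, which is a limit and not a number. Among these compounds, compound 1 also stands at a limit, so no step between compound 1 and compound 3 can be read: the limit of > 40000 nM in this assay, at which 3 of the 3 values shown sit. The compounds shown leave open whether hydrogen and nitro differ at all in this setting, since none of them has yielded a measured number.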